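Two Dithiocarbamate Benzamides and an Expectation for a Third

A few compounds are considered here, and "the series" means these few. Any claim that something is new, unique, unknown or untested is made for them only; others in the source may bear on it.

In a functional assay on A-375 cells (Homo sapiens) for antiproliferative activity, read by CCK-8 assay, with a stated time of 72 h, tested at 2 uM (on this read-out higher numbers stand for a stronger effect at the one concentration tested and lower numbers for a weaker effect), compound 1 `Nc1ccccc1NC(=O)c1ccc(CSC(=S)N2CCN(C(c3ccccc3)c3ccccc3)CC2)cc1` gives 8.7%. Compound 2 `CN(C(=S)SCc1ccc(C(=O)Nc2ccccc2N)cc1)c1cccnc1` gives 26.5% in this assay, the higher of the two numbers, and its gap to compound 1 lies beyond the scatter. Compound 3 `CCN(Cc1ccncc1)C(=S)SCc1ccc(C(=O)Nc2ccccc2N)cc1` differs from compound 2 in one place: ethyl((pyridin-4-yl)methyl)amino in place of methyl(pyridin-3-yl)amino on a thiocarbonyl carbon. Within the data shown here, no measured pair shows what this change does, so compound 3 is expected to stay close to compound 2, with a step of a number 1.5 percentage points lower from compound 2 to compound 3 (within the scatter) that is expected to lie within the scatter, in no sure direction. Compound 3 is therefore estimated at 25%, between 8% and 45%.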

Compound 3, a percentage reported as inhibition, at one concentration (the size of the read-out at that concentration, not a potency): 67.2%
Compound 3: middle estimate off by 42.2 percentage points, on the low side, and the stated range ends below it.
By their numbers in this assay, from the lowest: compound 1; then compound 2; then compound 3.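

On a thiocarbonyl carbon whose other neighbour is sulfur, the amino group proves to have a strong influence in this assay: putting ethyl((pyridin-4-yl)methyl)amino in place of methyl(pyridin-3-yl)amino gives a number 40.7 percentage points higher from compound 2 to compound 3 (beyond the scatter). Among these compounds, this is the first pair differing in one place, so it is the first direct reading of this position. Nothing available explains the step. On these data alone, the change combines several differences, so it remains open whether the ethyl, the methylene link or the pyridin-4-yl carries the step. As far as these compounds go, what a morpholine at this place would give also remains open.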